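A second chloro on the shared core, expected weight

The compounds below may be only part of what the source reports. "The series", "measured", "known", "first", "only" and "open" are said of these compounds alone.

compound 1 `ClCc1cccc(Cn2cnc3ncnc(Cl)c32)c1`: 32400 nM
compound 2 `ClCc1ccc(Cn2cnc3nc(Cl)nc(Cl)c32)cc1`: 28800 nM

Compound 1 stands highest of the two numbers in a functional assay on SW-620 cells (Homo sapiens) for cytotoxicity, read by sulforhodamine B assay, with a stated time of 48 h (on this read-out lower numbers stand for stronger inhibition of growth and higher numbers for weaker inhibition of growth), with compound 2 close beside it; the gap between them lies within the scatter, so the two read as equal. Within the data shown here, compound 2 differs from compound 1 in more than one place, and no single step connects them; their two values show only that both sit in the same weak range. Compound 3 `ClCc1cccc(Cn2cnc3nc(Cl)nc(Cl)c32)c1` is not yet measured. It differs from compound 1 by chloro in place of hydrogen on an aromatic carbon. Among the measured compounds shown here, no measured pair isolates this change, so the direction of the step is open; on the evidence of compound 2, which also carries chloro at this place and gives 28800 nM, the step is expected to be small. For compound 3 the estimated value is 26000 nM, between 11000 nM and 60000 nM. The expected step of a 1.2-fold lower number from compound 1 to compound 3 (0.10 log units; within the scatter) thus stays within the scatter.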

Compound 3, concentration for total growth inhibition: 1650 nM
Beside the measured number, compound 3's estimate is 16-fold (1.20 log units) above it, outside the stated range (below it).
By their numbers in this assay, from the lowest: compound 3; then compounds 2 and 1 (each within the scatter of the next).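

Placing chloro on this aromatic carbon, between two ring nitrogen atoms, gives a 20-fold lower number from compound 1 to compound 3 (1.29 log units; beyond the scatter) in this assay, so this position strongly affects the read-out, which the earlier compounds could not show. Among these compounds, the chloro alone does not guarantee that result: compound 2 also carries it and gives 28800 nM, whereas compound 3 gives 1650 nM in the same assay, so the low number appears only in the one compound that combines this chloro with the rest of compound 3. Nothing shown here accounts for the size of the step.

From the compounds shown here alone, whether an amine, a methoxy group or a fluoro at this place would lower the number as chloro does remains open. So does the effect of replacing the chloromethyl group of compound 3 with a methyl or a hydroxymethyl group.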